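A few compounds are considered here, and "the series" means these few. Any claim that something is new, unique, unknown or untested is made for them only; others in the source may bear on it.

In an ADME assay on BJ cells (Homo sapiens) for cytotoxicity, with a stated time of 72 h (on this read-out higher numbers stand for an effect only at larger amounts of compound and lower numbers for an effect already at smaller amounts), compound 3 (`COc1ccc(/C=C/[C@@](C)(/C=C/c2ccc(O)cc2)CCC=C(C)C)cc1`) gives > 36600 nM as a limit of the assay, not a number. Compound 1 (`CCOC(=O)/C=C/c1cc(/C=C/[C@](C)(/C=C/c2ccc(OC)cc2)CCC=C(C)C)ccc1O`) gives > 36600 nM as a limit too. Compound 2 (`COc1ccc(/C=C/[C@@](C)(/C=C/c2ccc(O)c(/C=C/C(=O)OCc3ccccc3)c2)CCC=C(C)C)cc1`) gives > 36600 nM as a limit too. The picture so far is the limit of > 36600 nM in this assay, at which 3 of the 3 values shown sit, and no true number among them, so compound 3 stands level with the others only in the sense that all three share one limit.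

Compound 4 (`CCOc1ccc(/C=C/[C@@](C)(/C=C/c2ccc(O)cc2)CCC=C(C)C)cc1`) differs from compound 3 at one spot (methyl in place of hydrogen on a saturated chain carbon bound to an oxygen on an aromatic ring): methyl in place of hydrogen on a saturated chain carbon bound to an oxygen on an aromatic ring, which turns 4-methoxyphenyl into 4-ethoxyphenyl.

Three measured steps lie elsewhere in the molecule and bear on this only loosely. They are (a step that the two limits leave unreadable from compound 1 to compound 3), (a step that the two limits leave unreadable from compound 2 to compound 3) and (a step that the two limits leave unreadable from compound 1 to compound 2). None has a readable size, yet these far bigger exchanges all end at the same limit, so for one added methyl no step beyond the usual scatter is expected in this assay in either direction. The estimated step is (a step that the limit leaves unreadable from compound 3 to compound 4). For compound 4 the estimated value is 40000 nM with an expected range from 22000 nM to 80000 nM and the assay will probably report only a limit.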

Compound 4, half-maximal effective concentration: > 36600 nM
Compound 4 was reported as a limit; the forecaster's own chance of this, stated with the estimate: 85%; the middle value lies beyond the limit too.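

Compound 3 and compound 4 both sit at a limit of the assay and not at a number, and the step between them has no readable size. The compounds shown leave open at what concentration any of them would affect the cells in this assay, and whether any exchanged group matters there, with every result at one shared limit: the limit of > 36600 nM in this assay, at which 4 of the 4 values shown sit.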